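Solubility Outlook for a Sulfonyl Piperidine Analogue

The compounds below may be only part of what the source reports. "The series", "measured", "known", "first", "only" and "open" are said of these compounds alone.

For the measured compounds named here, compound 1 `N[C@H]1CC[C@@H](Oc2ccc([C@H]3CC[C@]4(CC3)OOC3(O4)C4CC5CC(C4)CC3C5)cc2)CC1` holds the only plain number in a physicochemical assay for solubility, read by nephelometry, measured as kinetic solubility, with a stated time of 30 min; on this read-out higher numbers stand for higher solubility and lower numbers for lower solubility: compound 1 gives 25 ug/mL. Compound 2 `CC(C)(CN)Oc1ccc([C@H]2CC[C@]3(CC2)OOC2(O3)C3CC4CC(C3)CC2C4)cc1` sits at a limit of this assay, > 100 ug/mL, rather than at a number. Going by the values given here, the one measured step, an at least 4.0-fold higher number from compound 1 to compound 2 (0.60 log units; beyond the scatter), runs upward. Compound 3 `NC1CCN(S(=O)(=O)c2ccc([C@H]3CC[C@]4(CC3)OOC3(O4)C4CC5CC(C4)CC3C5)cc2)CC1` differs from compound 1 by (4-aminopiperidin-1-yl)sulfonyl in place of (4-aminocyclohexyl)oxy on an aromatic carbon. This change is not the one that was measured, so the step from compound 1 to compound 2 bears on it only loosely, and a modest rise rather than a fall is expected. The expected step is a 2.4-fold higher number from compound 1 to compound 3 (0.38 log units; beyond the scatter). Compound 3 is estimated at 60 ug/mL, between 20 ug/mL and 150 ug/mL.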

Compound 3, solubility: 12.5 ug/mL
Estimate against measurement, compound 3: 4.8-fold (0.68 log units) above; measured number below the stated range.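

On this assay, (4-aminopiperidin-1-yl)sulfonyl cannot be told apart from (4-aminocyclohexyl)oxy at this place, on an aromatic carbon para to a large group: a 2.0-fold lower number from compound 1 to compound 3 (0.30 log units; within the scatter). Against 1-(aminomethyl)-1-methylethoxy the same group gives a clear separation, an at least 8.0-fold lower number from compound 2 to compound 3 (0.90 log units; beyond the scatter), so compound 2 alone stands clear of the other two. Compound 2 gives a limit, not a number: the limit of > 100 ug/mL in this assay, at which 1 of the 3 values shown sits.

The compounds shown leave open how far compound 2 lies past that limit. They also leave open how a sulfonyl group bearing a morpholine, or a carboxylic acid in place of the amine, would read.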